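This account rests on a few compounds, and the source may have more. Where it says the series, first, only, none or still open, it means among the compounds named here.

Compound 1 `Cc1ncsc1CCOC(=O)c1oc2cc(-c3ccccc3)cc(O)c2c1C` gives 0.055 ug/mL in a functional assay on WI-38 VA13 cells (Homo sapiens) for cytotoxicity; a higher number here means that more compound is needed for the effect, a lower number that less compound is needed. Compound 2 `Cc1c(C(=O)Cc2ccccc2)oc2cc(-c3ccccc3)cc(O)c12` reaches only a limit of this assay, > 4 ug/mL. Compound 3 `Cc1c(C(=O)c2ccc(F)c(F)c2)oc2cc(-c3ccccc3)cc(O)c12` gives 0.4 ug/mL.

Compound 1 has the lowest number among the two values given as numbers; compound 3 lies nearest, with a 7.3-fold higher number from compound 1 to compound 3 (0.86 log units; beyond the scatter). Compound 4 `COc1ccc(CCOC(=O)c2oc3cc(-c4ccccc4)cc(O)c3c2C)cc1` differs from compound 1 by 4-methoxyphenyl in place of 4-methyl-1,3-thiazol-5-yl on a saturated chain carbon, two bonds along the chain from an oxygen next to a carbonyl group. Both measured steps from compound 1 alter the group on the carbonyl carbon itself and replace the whole ester, so neither tests a change out on the chain; the larger step was an at least 72-fold higher number from compound 1 to compound 2 (1.86 log units; beyond the scatter). With the ester kept intact, only a step within the scatter is expected, a 1.5-fold higher number from compound 1 to compound 4 (0.16 log units; within the scatter). Compound 4 is therefore estimated at 0.08 ug/mL, with a range from 0.03 ug/mL to 0.3 ug/mL.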

Compound 4, half-maximal effective concentration: 0.02 ug/mL
Beside the measured number, compound 4's estimate is 4.0-fold (0.60 log units) above it; the measured number lies below the stated range.
By their numbers in this assay, from the lowest: compound 4; then compound 1; then compound 3. At a limit, above all of these: compound 2.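

In this assay, 4-methoxyphenyl in place of 4-methyl-1,3-thiazol-5-yl gives a 2.8-fold lower number from compound 1 to compound 4 (0.44 log units; beyond the scatter), so a change out on the chain, with the ester kept, moves the number beyond the scatter. A low number therefore does not depend on the thiazole: a six-membered aromatic ring of carbon only serves at this position, and here the number is lower. Nothing measured here explains this step.

As far as these compounds go, whether a plain phenyl, or an amine or carboxylic acid in place of the methoxy group, would keep this number remains open. So does the effect of a longer chain.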